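The source may hold more compounds than are shown below. What is called first, only, known or untested is meant among the compounds shown, and "the series" means these compounds.

Measured compounds in a functional assay with growth hormone secretagogue receptor type 1 (Homo sapiens) as the target; a higher number here means a larger maximal response, a lower number a smaller maximal response:
Compound 1, `COc1cc2c(cc1N1C[C@@H](C)N[C@@H](C)C1)N(S(=O)(=O)c1ccc3ccccc3c1)CC2`, gives 1.
Compound 2, `COc1cc2c(cc1N1C[C@@H](C)N[C@@H](C)C1)N(S(=O)(=O)CCc1ccccc1Cl)CC2`, gives 0.9.
Compound 3, `COc1cc2c(cc1N1C[C@@H](C)N[C@@H](C)C1)N(S(=O)(=O)c1ccc(-c3ccccn3)s1)CC2`, gives 0.9.

The three measured compounds share one core and differ only in the group on the sulfonyl sulfur. Every step among them stays within the scatter: a number 0.10 lower from compound 1 to compound 2 (within the scatter), a number 0.10 lower from compound 1 to compound 3 (within the scatter) and no change at the digits printed from compound 2 to compound 3 (within the scatter). Compound 3 thus stands together with compound 2 at the lower of the recorded numbers, with compound 1 within the scatter of both; all three reach close to the full response of the reference agonist, so there is little room upward in this series.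

Compound 4, `COc1cc2c(cc1N1CCN[C@@H](C)C1)N(S(=O)(=O)c1ccc(-c3ccccn3)s1)CC2`, keeps the sulfonyl group of compound 3 and alters the saturated ring instead: hydrogen in place of methyl on a saturated ring carbon. For the measured compounds named here, none of the measured steps touches this ring, so no recorded step bears directly on the change; the measured steps show only that variation elsewhere in the molecule left the maximal response within the scatter. Lacking a step on this position, the working assumption is continuity with compound 3. Compound 4 is therefore expected to give 0.9 in this assay, with a range from 0.7 to 1. For compound 4 the expected step is no change at the digits printed from compound 3 to compound 4 (within the scatter), within the scatter.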

Compound 4, intrinsic activity: the largest response reached, as a fraction of the reference agonist's: 1
Beside the measured number, compound 4's estimate is 0.10 below it, within the range that was stated.
By their numbers in this assay, from the lowest: compounds 2, 3, 1 and 4 (each within the scatter of the next).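

In this assay, for the compounds shown here, 3-methylpiperazin-1-yl in place of 3,5-dimethylpiperazin-1-yl gives a number 0.10 higher from compound 3 to compound 4 (within the scatter), and this is the first measured step on the saturated ring. The earlier steps shown here covered only the group on the sulfonyl sulfur, whereas this one shows that, with the 5-(pyridin-2-yl)thiophen-2-yl sulfonyl group held fixed, one ring methyl can give way to hydrogen without the maximal response leaving the scatter. No measurement at hand offers an explanation for this result.

The compounds shown leave open whether the plain piperazin-1-yl group, with hydrogen on both ring carbons, or an ethyl group on the same ring carbon would also stay within the scatter in this assay, and what a methyl group on the ring nitrogen would do. They also leave open whether the same exchange behaves alike with naphthalen-2-yl or 2-(2-chlorophenyl)ethyl on the sulfonyl sulfur, and this read-out of maximal response says nothing about the concentration needed to reach that response.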